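The compounds below may be only part of what the source reports. "The series", "measured", "known", "first", "only" and "open" are said of these compounds alone.

Working notes on the series. The shared core carries an aryl on the amine nitrogen and a second aryl on the ring system; compound 1 `COc1ccc(N/C=C\C(=O)c2nc(-c3ccc(F)cc3)n3ccccc23)cc1` has a 4-methoxyphenyl on the amine and gives 2560 nM in a functional assay on B16-F10 cells (Mus musculus) for cytotoxicity, read by MTT assay, with a stated time of 48 h; on this read-out higher numbers stand for weaker inhibition and lower numbers for stronger inhibition. Compound 2 `COc1ccc(-c2nc(C(=O)/C=C\Nc3ccc(Cl)cc3)c3ccccn23)cc1` carries a 4-chlorophenyl on the amine and a 4-methoxyphenyl on the core, and in this assay compound 2 gives 1240 nM. Compound 3 `COc1ccc(N/C=C\C(=O)c2nc(-c3ccc(F)cc3)n3ccccc23)cc1OC` adds a second methoxy to the amine aryl. In this assay, going by the values given here, compound 3 sits at > 30000 nM, which is a limit of the assay and not a number, and it is the one value of the three that rests at the limit of > 30000 nM in this assay, at which 1 of the 3 values shown sits. Among the compounds with values here, the one measured step that reaches compound 3 is an at least 11-fold higher number from compound 1 to compound 3 (1.06 log units; beyond the scatter).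

Compound 4 `O=C(/C=C\Nc1ccc(Cl)cc1)c1nc(-c2ccc(F)cc2)n2ccccc12` is not yet measured. The change is 4-chlorophenyl in place of 3,4-dimethoxyphenyl on an amine nitrogen. It undoes the dimethoxy pattern of compound 3 and installs the same amine aryl that compound 2 carries, while the core aryl of compound 1 and compound 3 stays. Since the step from compound 1 to compound 3 was large, the reverse direction, back to a single-substituted amine aryl, is expected to bring a large drop in the number. Compound 4 is therefore expected at about 1800 nM, within 600 nM to 6000 nM, which means an expected step of an at least 16-fold lower number from compound 3 to compound 4 (1.22 log units; beyond the scatter).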

Compound 4, half-maximal inhibitory concentration: 11000 nM
Estimate against measurement, compound 4: 6.1-fold (0.79 log units) below; the whole stated range lies below it.
By their numbers in this assay, from the lowest: compound 2; then compound 1; then compound 4. At a limit, above all of these: compound 3.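

With the 4-fluorophenyl on the core held, chloro in place of methoxy on the amine aryl gives a 4.3-fold higher number from compound 1 to compound 4 (0.63 log units; beyond the scatter) in this assay, so the single substituent on this aryl matters, and the methoxy of compound 1 is not matched by chloro here. The second methoxy is not the only feature that sets the number, since replacing 3,4-dimethoxyphenyl with 4-chlorophenyl on the amine nitrogen gives only an at least 2.7-fold lower number from compound 3 to compound 4 (0.43 log units; beyond the scatter), and that step is a bound and not a measured size, as compound 3 stands at a limit of the assay: the limit of > 30000 nM in this assay, at which 1 of the 4 values shown sits. Going by these compounds alone, with the 4-chlorophenyl on the amine held, fluoro in place of methoxy on the core aryl gives an 8.9-fold higher number from compound 2 to compound 4 (0.95 log units; beyond the scatter), which shows for the first time that the core aryl also moves the number.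

The compounds shown leave open whether the methoxy preference on the core aryl holds with other amine aryls, so how the two aryl positions combine remains unsettled. Also open, on these data alone, is how either aryl would respond to a dimethylamino group or a carboxylic acid in place of the methoxy, fluoro or chloro substituents.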